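Chain extension on a hydroxamic acid and its expected effect

The source may hold more compounds than are shown below. What is called first, only, known or untested is meant among the compounds shown, and "the series" means these compounds.

Measured so far:
compound 1, `C#CCN(C)Cc1cccc(NC(=O)CCC(=O)NO)c1`, > 10000 nM
compound 2, `C#CCN(C)Cc1cccc(NC(=O)CCCCCC(=O)NO)c1`, 4290 nM
compound 3, `C#CCN(C)Cc1ccc(NC(=O)CCCCC(=O)NO)cc1`, > 10000 nM

In a functional assay on DU-145 cells (Homo sapiens) for inhibition, read by MTT assay, with a stated time of 48 h (on this read-out lower numbers stand for stronger inhibition of growth and higher numbers for weaker inhibition of growth), compound 3 gives only a limit, > 10000 nM, so no number is known for it. Compound 4, `C#CCN(C)Cc1ccc(NC(=O)CCCCCCCCC(=O)NO)cc1`, has not been measured. It differs from compound 3 by one change: 4-(hydroxycarbamoyl)butyl in place of hydroxycarbamoyl on a saturated chain carbon, four bonds along the chain from a carbonyl carbon. The closest comparison among measured pairs is compound 1 to compound 2, where a shorter extension of the same kind gave an at least 2.3-fold lower number from compound 1 to compound 2 (0.36 log units; beyond the scatter). Compound 1 also sits at a limit, > 10000 nM, as does compound 3, a point summarised by the limit of > 10000 nM in this assay, at which 2 of the 3 values shown sit. Since a longer chain on the shared core moved the value below the limit in that pair, compound 4 is expected to fall below the limit too, in the same direction, by a step of about an at least 3.3-fold lower number from compound 3 to compound 4 (0.52 log units; beyond the scatter), though the spread is wide. The estimate for compound 4 in this assay is 3000 nM, with a range from 700 nM to 10000 nM.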

Compound 4, concentration for 50% growth inhibition: 2740 nM
The estimate for compound 4 lay 1.1-fold (0.04 log units) above the measured number; low and high end bracket the measured number.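

In this assay, placing 4-(hydroxycarbamoyl)butyl in place of hydroxycarbamoyl gives an at least 3.6-fold lower number from compound 3 to compound 4 (0.56 log units; beyond the scatter), so chain extension lowers the number on the core of compound 3 as well as on the core of compound 1. Compound 3 gives only a limit, > 10000 nM, and not a number. The true size of the step therefore remains unknown, and limits make up a large share of this small set: the limit of > 10000 nM in this assay, at which 2 of the 4 values shown sit.

The compounds shown leave open whether a longer chain than that of compound 4 would lower the number further or whether the trend stops at some length. They also leave open whether the chain alone is enough, since a carboxylic acid at the chain end in place of the hydroxycarbamoyl group is not among them.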